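Swapping bromo for fluoro on a benzyl pair with low numbers

This account rests on a few compounds, and the source may have more. Where it says the series, first, only, none or still open, it means among the compounds named here.

Compound 2, `CN(Cc1ccc(Br)cc1)Cc1nn(-c2ccccc2F)c2c1CCS(=O)(=O)O2`: 0.2%
Compound 1, `CCN(Cc1ccc(F)cc1)Cc1nn(-c2ccccc2F)c2c1CCS(=O)(=O)O2`: 0.6%

In a functional assay, with a stated time of 2 h, tested at 100 uM (on this read-out higher numbers stand for more inhibition at the one concentration tested (going by the name of the read-out) and lower numbers for less inhibition), compound 2 gives 0.2%, the lowest of the two numbers. Compound 1 gives 0.6%, which lies within the scatter of that, so no order between the two can be read. Compound 3, `CN(Cc1ccc(F)cc1)Cc1nn(-c2ccccc2F)c2c1CCS(=O)(=O)O2`, differs from compound 2 by fluoro in place of bromo on an aromatic carbon. For the measured compounds named here, no measured pair shows this change, so its size is not known here. Both measured compounds sit at low numbers in this assay, and the step of a number 0.3 percentage points higher from compound 2 to compound 3 (within the scatter) is expected to stay within the scatter. Compound 3 is estimated at 0.5%, with a range of -5% to 8%.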

Compound 3, a percentage reported as inhibition, at one concentration (the size of the read-out at that concentration, not a potency): 5.7%
Compound 3: the middle estimate sits 5.2 percentage points below what was measured; the range from low to high includes it.
By their numbers in this assay, from the lowest: compounds 2, 1 and 3 (each within the scatter of the next).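

In this assay the change from 4-bromobenzyl to 4-fluorobenzyl now has a measured pair, and it gives a number 5.5 percentage points higher from compound 2 to compound 3 (within the scatter) so this swap shows no effect that can be told from the scatter. Hydrogen in place of methyl on the saturated chain carbon bound to the amine nitrogen gives a number 5.1 percentage points higher from compound 1 to compound 3 (within the scatter) and this position likewise shows no readable difference. No measured evidence bears on these results.

Going by these compounds, whether a nitrile or a carboxylic acid in place of the fluoro would give a clearer reading remains open. So does the effect of a longer chain on the amine.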